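This account rests on a few compounds, and the source may have more. Where it says the series, first, only, none or still open, it means among the compounds named here.

In a toxicity assay on A549 cells (Homo sapiens) for cytotoxicity, read by luminescence and CellTiter-Glo, with a stated time of 48 h (on this read-out lower numbers stand for higher toxicity in this test and higher numbers for lower toxicity in this test), compound 1 `COCCOc1ccc(-c2nc3ncccn3c2NC2CCCCC2)cc1` gives only a limit of the assay, > 100000 nM. For the measured compounds named here, compound 2 `Fc1ccc(-c2nc3ncccn3c2NC2CCCCC2)cc1` gives 100000 nM, the only actual number so far. Compound 3 `Oc1cccc(-c2nc3ncccn3c2NC2CCCCC2)c1` has 3-hydroxyphenyl in place of 4-fluorophenyl on an aromatic carbon. Going by the values given here, the one measured step, a number no higher from compound 1 to compound 2 (the limit leaves the size open), also swaps a group on an aromatic carbon, but its size cannot be read, as the limit of > 100000 nM in this assay, at which 1 of the 2 values shown sits, shows. With so little to go on, the estimated step of a 1.3-fold lower number from compound 2 to compound 3 (0.10 log units; within the scatter) is expected to stay within the usual scatter of this assay. Compound 3 is expected at 80000 nM, with an estimated range from 30000 nM to 100000 nM.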

Compound 3, half-maximal cytotoxic concentration: 100000 nM
Compound 3: the middle estimate sits 1.3-fold (0.10 log units) below what was measured; the measured number falls inside the stated range.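

In this assay the swap on this aromatic carbon gives no change at the digits printed from compound 2 to compound 3 (within the scatter) and so, unlike the earlier step, which cannot be read, has a size that can be stated. Here, 3-hydroxyphenyl brings a hydrogen-bond donor and acceptor that 4-fluorophenyl lacks, yet the printed number stays the same. This flat result carries limited weight: the limit of > 100000 nM in this assay, at which 1 of the 3 values shown sits. Still open, on these data alone, is whether an amine or a carboxylic acid on this phenyl ring, or a longer chain in place of the cyclohexylamino group, would give a lower number.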